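Swapping the aryl group on a sulfonamide nitrogen

The source may hold more compounds than are shown below. What is called first, only, known or untested is meant among the compounds shown, and "the series" means these compounds.

In a functional assay on cells (leukaemia cell line, Homo sapiens) for inhibition, read by sulforhodamine B assay, with a stated time of 48 h (on this read-out higher numbers stand for weaker inhibition of growth and lower numbers for stronger inhibition of growth), compound 1 `O=S(=O)(Nc1cccc(Cl)c1)c1ccc(-c2cnc(C3CC3)o2)cc1` gives 54200 nM. Compound 2 `O=S(=O)(Nc1cc(Cl)ccc1Cl)c1ccc(-c2cnc(C3CC3)o2)cc1` reaches only a limit in this assay, at > 100000 nM, so it has no exact place on the scale. Its position is the limit of > 100000 nM in this assay, at which 1 of the 2 values shown sits.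

The next structure, compound 3 `Cc1cc(F)cc(NS(=O)(=O)c2ccc(-c3cnc(C4CC4)o3)cc2)c1`, carries one change: 3-fluoro-5-methylphenyl in place of 2,5-dichlorophenyl on a sulfonamide nitrogen. The 2,5-dichlorophenyl leaves and the 3-fluoro-5-methylphenyl enters on a sulfonamide nitrogen. Going by the values given here, the only measured step that bears on this is an at least 1.8-fold higher number from compound 1 to compound 2 (0.26 log units; that floor lies within the scatter), and it gives no firm size. Among the compounds with values here, the expectation therefore leans on compound 1 at 54200 nM, the only exact number available. A limit reading for compound 3 also remains possible. A modest move toward a lower number is expected, with the estimated step being an at least 1.5-fold lower number from compound 2 to compound 3 (0.18 log units; that floor lies within the scatter). The estimate for compound 3 is 65000 nM, with an expected range of 30000 nM to 100000 nM.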

Compound 3, concentration for total growth inhibition: 7250 nM
Compound 3: middle estimate off by 9.0-fold (0.95 log units), on the high side, outside the stated range (below it).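

The group on the sulfonamide nitrogen turns out to matter a great deal in this assay, which the first pair could not establish: 3-fluoro-5-methylphenyl in place of 2,5-dichlorophenyl gives an at least 13-fold lower number from compound 2 to compound 3 (1.13 log units; beyond the scatter). That step is only a floor, and compound 2 is a limit rather than a number: the limit of > 100000 nM in this assay, at which 1 of the 3 values shown sits. The comparison with 3-chlorophenyl does not rest on a limit, and it gives a 7.5-fold lower number from compound 1 to compound 3 (0.87 log units; beyond the scatter), so the change of aryl group moves the reading clearly even between two exact values.

As far as these compounds go, compound 3 carries the fluoro and the methyl together, and the share of each in this step remains open. Also open, from the compounds shown here alone, is whether a methoxy group or an amine on the phenyl group would hold the reading at this level.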